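A few compounds are considered here, and "the series" means these few. Any claim that something is new, unique, unknown or untested is made for them only; others in the source may bear on it.

Compound 1: `CCCN(CC1CC1)c1cc(C)nc2c(-c3cnc(N(C)C)cc3C)c(C)nn12` gives 2.6 nM in an assay on CHO cells for binding affinity to corticotropin-releasing factor receptor 1 (Homo sapiens); on this read-out higher numbers stand for weaker inhibition and lower numbers for stronger inhibition.
Compound 2: `Cc1cc(N(Cc2ccccc2)C(C)C)n2nc(C)c(-c3cnc(N(C)C)cc3C)c2n1` gives 11 nM in this assay.

Of the two measured compounds, compound 2 stands at the higher number, and its distance from compound 1 lies beyond the usual scatter. Compound 3, `CCCN(Cc1ccccc1)c1cc(C)nc2c(-c3cnc(N(C)C)cc3C)c(C)nn12`, is not yet measured. It differs from compound 2 in one place: propyl in place of isopropyl on a nitrogen on an aromatic ring. Among the compounds with values here, no measured pair shows this exact change, so the direction is uncertain. A small step is expected, if any, from compound 2 to compound 3, a 1.6-fold lower number from compound 2 to compound 3 (0.20 log units; within the scatter), most likely not beyond the scatter. Compound 3 is estimated at 7 nM, within a range from 2.5 nM to 20 nM.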

Compound 3, inhibition constant: 5.2 nM
Beside the measured number, compound 3's estimate is 1.3-fold (0.13 log units) above it; measured number inside the range.
By their numbers in this assay, from the lowest: compounds 1 and 3 (each within the scatter of the next); then compound 2.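

Swapping isopropyl for propyl on this nitrogen keeps the same atoms but still matters in this assay: the step is a 2.1-fold lower number from compound 2 to compound 3 (0.33 log units; beyond the scatter), a modest change from rearranging the chain alone. With propyl kept on the nitrogen, placing phenyl where cyclopropyl stood gives a 2.0-fold higher number from compound 1 to compound 3 (0.30 log units; within the scatter), so these two groups cannot be told apart here. No measurement shown explains either step.

Still open, as far as these compounds go, is whether a longer chain, such as butyl, would continue the change seen from isopropyl to propyl. Also open, from the compounds shown here alone, is how a cyclopropyl partner would respond to isopropyl on this nitrogen.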